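A Methyl on the Chain and Expected Solubility

This account rests on a few compounds, and the source may have more. Where it says the series, first, only, none or still open, it means among the compounds named here.

Three compounds have been measured in a physicochemical assay for solubility, read by HPLC, in phosphate buffer, with a stated time of 24 h, at pH 7.4, tested at 100 uM; on this read-out lower numbers stand for lower solubility and higher numbers for higher solubility:

Compound 1 `O=C(CCCCCNc1c(Nc2ccccc2)c(=O)c1=O)NO` gives 47000000 nM.
Compound 2 `C[C@H](Nc1c(NCCCCCC(=O)NO)c(=O)c1=O)c1ccccc1` gives 73000000 nM.
Compound 3 `CC[C@H](Nc1c(NCCCCCC(=O)NO)c(=O)c1=O)c1ccccc1` gives 75000000 nM.

Compound 1 and compound 2 differ in their cores: phenyl in place of 1-phenylethyl on a nitrogen on an aromatic ring. That change gives a 1.6-fold higher number from compound 1 to compound 2 (0.19 log units; within the scatter). From compound 2 to compound 3 the change is methyl in place of hydrogen on a saturated chain carbon, two bonds along the chain from an aromatic carbon and a nitrogen on an aromatic ring, and in this assay it gives a 1.0-fold higher number from compound 2 to compound 3 (0.01 log units; within the scatter). All three values lie within the scatter of one another, so none of them can be called more or less soluble than the others.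

Compound 4 `CC(CCCCC(=O)NO)Nc1c(Nc2ccccc2)c(=O)c1=O` has not yet been measured in this assay. It differs from compound 1 by methyl in place of hydrogen on a saturated chain carbon bound to a nitrogen on an aromatic ring and a saturated chain carbon. For the measured compounds named here, this is the same kind of change as the one from compound 2 to compound 3, though not the same: there the methyl enters on a saturated chain carbon two bonds along the chain from an aromatic carbon and a nitrogen on an aromatic ring, whereas here it enters on a saturated chain carbon bound to a nitrogen on an aromatic ring and a saturated chain carbon. Going by the values given here, the only precedent for adding a methyl on this chain is the step from compound 2 to compound 3, which stayed within the scatter. On that basis compound 4 is expected to show a 1.1-fold higher number from compound 1 to compound 4 (0.03 log units; within the scatter), a step of about the same size as the earlier one. The estimate for compound 4 is 50000000 nM, with an expected range from 25000000 nM to 100000000 nM. This expectation rests on compound 1 at 47000000 nM and on the earlier step of a 1.0-fold higher number from compound 2 to compound 3 (0.01 log units; within the scatter).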

Compound 4, solubility: 93000000 nM
Compound 4: the middle estimate sits 1.9-fold (0.27 log units) below what was measured; measured number inside the range.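

In this assay, methyl in place of hydrogen on a saturated chain carbon bound to a nitrogen on an aromatic ring and a saturated chain carbon gives a 2.0-fold higher number from compound 1 to compound 4 (0.30 log units; within the scatter), and the earlier methyl step gives a 1.0-fold higher number from compound 2 to compound 3 (0.01 log units; within the scatter), so on both cores the added methyl stays within the scatter. This does not show that one change was carried from one core to another, since the methyl enters at a different place in each pair, and two pairs cannot establish a rule for the series or show what the same methyl would do at the other place on either core. No measurement offered here bears on what lies behind these numbers.

The compounds shown leave open whether an amine, a hydroxyl or a carboxylic acid entering on that saturated chain carbon would also stay within the scatter, on the core of compound 1 or on that of compound 2. They also leave open whether a longer chain in place of the methyl would give a step that could be read beyond the scatter.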